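Swapping methoxy for chloro in compound 3

A few compounds are considered here, and "the series" means these few. Any claim that something is new, unique, unknown or untested is made for them only; others in the source may bear on it.

Compound 1 `COc1ccc(/C=C\c2cc(OC)c(OC)c(OC)c2)cc1OCc1ccccc1`: 59000 nM
Compound 2 `COc1ccc(COc2cc(/C=C\c3cc(OC)c(OC)c(OC)c3)ccc2OC)cc1`: 48000 nM
Compound 3 `COc1ccc(/C=C/CCCOc2cc(/C=C\c3cc(OC)c(OC)c(OC)c3)ccc2OC)cc1`: 16000 nM

All three values come from a functional assay on MCF7 cells (Homo sapiens) for inhibition, read by MTT assay, with a stated time of 3 days; on this read-out lower numbers stand for stronger inhibition and higher numbers for weaker inhibition. Compound 3 has the lowest of the three numbers, and both steps leading to it lie beyond the scatter: a 3.7-fold lower number from compound 1 to compound 3 (0.57 log units; beyond the scatter) and a 3.0-fold lower number from compound 2 to compound 3 (0.48 log units; beyond the scatter). The next compound to consider is compound 4 `COc1ccc(/C=C\c2cc(OC)c(OC)c(OC)c2)cc1OCCC/C=C/c1ccc(Cl)cc1`, which differs from compound 3 in a single group: chloro in place of methoxy on an aromatic carbon. This puts chloro in place of methoxy on an aromatic carbon of a six-membered aromatic ring of carbon only, para to a large group.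

Among the compounds with values here, no measured step makes this exact swap. The closest is a 1.2-fold lower number from compound 1 to compound 2 (0.09 log units; within the scatter), where methoxy replaces hydrogen on an aromatic carbon, and that step stays within the scatter. Within the data shown here, it is only one example and involves hydrogen rather than chloro, so it offers limited guidance. The two larger steps into compound 3 replace a much bigger piece of the molecule, so they say little about this small exchange. No step beyond the scatter is therefore expected in this assay. The estimated step is a 1.1-fold lower number from compound 3 to compound 4 (0.03 log units; within the scatter). Compound 4 is expected at 15000 nM, with an estimated range from 6000 nM to 40000 nM.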

Compound 4, half-maximal inhibitory concentration: 40000 nM
The estimate for compound 4 lay 2.7-fold (0.43 log units) below the measured number; low and high end bracket the measured number.
By their numbers in this assay, from the lowest: compound 3; then compounds 4, 2 and 1 (each within the scatter of the next).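

Within the data shown here, this is the first measured step at this position, on an aromatic carbon of a six-membered aromatic ring of carbon only, para to a large group. In this assay the exchange of methoxy for chloro on that ring gives a step beyond the scatter (a 2.5-fold higher number from compound 3 to compound 4 (0.40 log units; beyond the scatter)), so the group at the end of the chain does matter. The result also changes how the longer chain reads: with chloro in place of methoxy, the 4-(4-chlorophenyl)but-3-en-1-yl compound stays within the scatter of both shorter-armed compounds (a 1.2-fold lower number from compound 2 to compound 4 (0.08 log units; within the scatter); a 1.5-fold lower number from compound 1 to compound 4 (0.17 log units; within the scatter)), so the lower number of compound 3 belongs to the chain and the methoxy together, not to the chain alone. Nothing measured here speaks to the reason for this difference.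

From the compounds shown here alone, only methoxy and chloro appear at this position, so it remains open whether hydrogen, hydroxy or an amine there would stay close to compound 3 or to compound 4. Going by these compounds, it is also open whether a shorter or longer chain carrying the methoxy would keep the lower number of compound 3.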